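Methanesulfonamido Chain in Place of the Aminohydroxy Chain

The source may report more compounds than this note shows. Statements on the series, on what has been measured and on what is new or still open speak of the compounds shown alone.

In an assay on striatum for inhibition of 5-hydroxytryptamine receptor 4 (Cavia porcellus), read by radioligand binding (on this read-out lower numbers stand for stronger inhibition and higher numbers for weaker inhibition), compound 3 `COc1cc(N)c(Cl)cc1C(=O)NC1CCN(CC2CCN(CC(O)CN)CC2)CC1` gives 14.4 nM, the highest of the three numbers measured. Compound 1 `COc1cc(N)c(Cl)cc1C(=O)NC1CCN(CC2CCN(C(=O)CCCN)CC2)CC1` gives 3.99 nM and compound 2 `COc1cc(N)c(Cl)cc1C(=O)NC1CCN(CC2CCN(C(=O)C(C)N)CC2)CC1` gives 5.06 nM; between them there is a 1.3-fold higher number from compound 1 to compound 2 (0.10 log units; within the scatter). Going to compound 3 the numbers rise by a 3.6-fold higher number from compound 1 to compound 3 (0.56 log units; beyond the scatter) and by a 2.8-fold higher number from compound 2 to compound 3 (0.45 log units; beyond the scatter), so the group on the ring amine nitrogen does move this assay, though only modestly.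

Compound 4 `COc1cc(N)c(Cl)cc1C(=O)NC1CCN(CC2CCN(CCCNS(C)(=O)=O)CC2)CC1` differs from compound 3 in one place: 2-(methanesulfonamido)ethyl in place of 2-amino-1-hydroxyethyl on a saturated chain carbon bound to an amine nitrogen in a ring. Among the compounds with values here, no measured step changes this chain in the same way; the two steps into compound 3 only show that exchanging the substituent on that nitrogen shifts the number by a modest amount in either direction. A step of comparable size is therefore expected here, with its direction uncertain. Compound 4 is estimated at 15 nM with a range from 5 nM to 60 nM. This estimate corresponds to an expected step of a 1.0-fold higher number from compound 3 to compound 4 (0.02 log units; within the scatter).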

Compound 4, half-maximal inhibitory concentration: 21.1 nM
Compound 4: middle estimate off by 1.4-fold (0.15 log units), on the low side; the measured number falls inside the stated range.
By their numbers in this assay, from the lowest: compounds 1 and 2 (each within the scatter of the next); then compounds 3 and 4 (each within the scatter of the next).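

In this assay, the result shows that on a saturated chain carbon bound to an amine nitrogen in a ring, 2-(methanesulfonamido)ethyl and 2-amino-1-hydroxyethyl cannot be told apart, with a 1.5-fold higher number from compound 3 to compound 4 (0.17 log units; within the scatter). The steps of a 4.2-fold higher number from compound 2 to compound 4 (0.62 log units; beyond the scatter) and a 5.3-fold higher number from compound 1 to compound 4 (0.72 log units; beyond the scatter) are both modest and show that, among these four compounds, the two with a carbonyl on the ring amine nitrogen give lower numbers than the two without one, and no compound goes against this. Nothing measured here accounts for these steps.

Going by these compounds, what stays open is how a methanesulfonamido end would behave on a chain that keeps the carbonyl on the ring amine nitrogen. On these data alone, the effect of a carboxylic acid or a longer chain on that nitrogen also remains open.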